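Amino Substitution on Two Thiophene Nucleosides

The source may hold more compounds than are shown below. What is called first, only, known or untested is meant among the compounds shown, and "the series" means these compounds.

Compound 1 `COc1ncnc2c1c(-c1ccsc1)cn2[C@@H]1O[C@H](CO)[C@@H](O)[C@H]1O` and compound 3 `COc1ncnc2c1c(-c1cccs1)cn2[C@@H]1O[C@H](CO)[C@@H](O)[C@H]1O` share one core and are built from the same atoms; the counted difference between them is thiophen-2-yl in place of thiophen-3-yl on an aromatic carbon. In a functional assay on CCRF-CEM cells (Homo sapiens), read by MTT assay, with a stated time of 72 h (on this read-out higher numbers stand for weaker inhibition and lower numbers for stronger inhibition), compound 1 gives 2570 nM, while compound 3 gives 90 nM, so that the step of a 29-fold lower number from compound 1 to compound 3 (1.46 log units; beyond the scatter) is the widest gap among the measured values. Compound 2 `COc1nc(N)nc2c1c(-c1ccsc1)cn2[C@@H]1O[C@H](CO)[C@@H](O)[C@H]1O` differs from compound 1 by amino in place of hydrogen on an aromatic carbon. In this assay compound 2 reaches only > 20000 nM, which is a limit of the assay and not a number. The step of an at least 7.7-fold higher number from compound 1 to compound 2 (0.89 log units; beyond the scatter) therefore rests on that limit (the limit of > 20000 nM in this assay, at which 1 of the 3 values shown sits).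

Compound 4 `COc1nc(N)nc2c1c(-c1cccs1)cn2[C@@H]1O[C@H](CO)[C@@H](O)[C@H]1O`, not yet measured, is related to compound 3 by amino in place of hydrogen on an aromatic carbon; the place is described in the same words as for compound 2, so this is the same change made on the core of compound 3. Because the measured step of an at least 7.7-fold higher number from compound 1 to compound 2 (0.89 log units; beyond the scatter) was at least modest, compound 4 is expected to show a step of a 17-fold higher number from compound 3 to compound 4 (1.22 log units; beyond the scatter) in this assay. Compound 4 is thus estimated at 1500 nM, within 300 nM to 8000 nM.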

Compound 4, half-maximal inhibitory concentration: > 20000 nM
Compound 4 gave a limit, no number; the forecaster's own chance of this, stated with the estimate: 15%; at least 13-fold (1.12 log units) between middle value and limit.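

In this assay compound 4 gives > 20000 nM, which is a limit of the assay and not a number. Amino in place of hydrogen on an aromatic carbon therefore moves the number the same way on the second core, giving an at least 220-fold higher number from compound 3 to compound 4 (2.34 log units; beyond the scatter), and the two steps can be set side by side: the same change on two cores in this assay, an at least 7.7-fold higher number (0.89 log units; beyond the scatter) from compound 1 to compound 2 and an at least 220-fold higher number (2.34 log units; beyond the scatter) from compound 3 to compound 4; the limit leaves it open whether they differ. The direction of the change carries from one core to the other, but this does not show that its size carries, and the step from compound 2 to compound 4 cannot be read either: the limit of > 20000 nM in this assay, at which 2 of the 4 values shown sit.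

The compounds shown leave open how far the amino group lowers activity on each core, since neither amino compound gives a number. They also leave open whether a different group on that aromatic carbon, such as methyl or a methylamino group, would keep the gap between the thiophen-2-yl and thiophen-3-yl compounds readable.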